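A Shorter Chain on the Core of Compound 1

The compounds below may be only part of what the source reports. "The series", "measured", "known", "first", "only" and "open" are said of these compounds alone.

Measured so far in a functional assay on HepG2 cells (Homo sapiens) for inhibition, read by MTT assay, with a stated time of 48 h; on this read-out lower numbers stand for stronger inhibition and higher numbers for weaker inhibition
Compound 1 `COc1ccc(N(C)c2nc(C)nc3ccccc23)cc1C(=O)OCCC[Se]C#N` gives 340 nM
Compound 2 `C[Se]c1ccc(N(C)c2nc(C)nc3ccccc23)cc1Cl` gives 4 nM

Compound 1 has the higher of the two numbers, and its gap to compound 2 lies beyond the usual scatter. Compound 3 `COc1ccc(N(C)c2nc(C)nc3ccccc23)cc1OCCN` keeps the core of compound 1 and differs in one place. Its selenium-bearing chain gives way to 2-aminoethoxy, on an aromatic carbon ortho to a methoxy group (a group of 4 heavy atoms (2 carbon, 1 nitrogen, 1 oxygen; no ring) in place of a group of 9 heavy atoms (5 carbon, 1 nitrogen, 2 oxygen, 1 selenium; no ring), on an aromatic carbon). Within the data shown here, no measured pair isolates this change, so the guidance is thin. Compound 2 at 4 nM shows that much lower numbers occur among compounds of this family. The expected result is a 3.4-fold lower number from compound 1 to compound 3 (0.53 log units; beyond the scatter) in this assay, a moderate move toward stronger inhibition with wide uncertainty. Compound 3 is estimated at 100 nM with an expected range from 15 nM to 600 nM in this test.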

Compound 3, half-maximal inhibitory concentration: 343 nM
The estimate for compound 3 lay 3.4-fold (0.54 log units) below the measured number; the range from low to high includes it.
By their numbers in this assay, from the lowest: compound 2; then compounds 1 and 3 (each within the scatter of the next).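

On an aromatic carbon ortho to a methoxy group, replacing the selenium-bearing chain with 2-aminoethoxy in this assay gives a 1.0-fold higher number from compound 1 to compound 3 (0.00 log units; within the scatter) on the shared core. For this pair, then, a chain of 9 heavy atoms containing selenium and a chain of 4 heavy atoms without it cannot be told apart on this read-out, so selenium is not needed here to reach the number seen for compound 1. No supporting measurement explains why these two chains read alike.

Going by these compounds, it remains open whether a longer chain ending in an amine would read the same on this carbon, or whether a shorter one would. A carboxylic acid at this position, or a chain that keeps the nitrile but has no selenium, could also show whether this position tolerates other changes.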